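Ester Ring Size and Adenosine Receptor Binding

The source may report more compounds than this note shows. Statements on the series, on what has been measured and on what is new or still open speak of the compounds shown alone.

Compound 1, `CC1=C(C(=O)OC2CCC2)C(c2ccco2)NC(=O)N1`: 95.1 nM
Compound 2, `CC1=C(C(=O)OC2CCCC2)C(c2ccco2)NC(=O)N1`: 577 nM
Compound 3, `CC1=C(C(=O)OC2CCC2)C(c2ccsc2)NC(=O)N1`: 405 nM

All three compounds were tested in an assay on membranes from HEK293 cells for displacement of a labelled ligand from adenosine receptor A2b (Homo sapiens), read by scintillation counting, with a stated time of 30 min; a higher number here means a weaker inhibitor, a lower number a stronger inhibitor. Compound 1 gives the lowest number of the three. Going from compound 1 to compound 2, the change is cyclopentyl in place of cyclobutyl on an oxygen next to a carbonyl group; the result is a 6.1-fold higher number from compound 1 to compound 2 (0.78 log units; beyond the scatter). Going from compound 1 to compound 3, the change is thiophen-3-yl in place of furan-2-yl on a saturated ring carbon; here the result is a 4.3-fold higher number from compound 1 to compound 3 (0.63 log units; beyond the scatter). Compound 2 and compound 3 give numbers that lie within the usual scatter of each other, so no order between them can be read from these data.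

Compound 4, `CC1=C(C(=O)OC2CCCC2)C(c2ccsc2)NC(=O)N1`, has not yet been measured in this assay. It relates to compound 3 as compound 2 relates to compound 1: the change is cyclopentyl in place of cyclobutyl on an oxygen next to a carbonyl group, at the same place in the molecule, so it is the same change, applied to a core that carries thiophen-3-yl instead of furan-2-yl. Going by the values given here, with only one earlier example of this change, the expectation for compound 4 rests on the single observed step of a 6.1-fold higher number from compound 1 to compound 2 (0.78 log units; beyond the scatter) and on the starting value of compound 3, 405 nM. A step of similar size, perhaps somewhat smaller since the two cores are not identical, is expected from compound 3 to compound 4, a 4.9-fold higher number from compound 3 to compound 4 (0.69 log units; beyond the scatter). For compound 4 the estimated value in this assay is therefore 2000 nM, with a plausible range from 700 nM to 6000 nM.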

Compound 4, inhibition constant: 659 nM
Compound 4: middle estimate off by 3.0-fold (0.48 log units), on the high side; the measured number lies below the stated range.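

In this assay, cyclopentyl in place of cyclobutyl on the core carrying thiophen-3-yl gives a 1.6-fold higher number from compound 3 to compound 4 (0.21 log units; within the scatter), which does not match the step seen on the core carrying furan-2-yl: the same change on two cores in this assay, a 6.1-fold higher number (0.78 log units; beyond the scatter) from compound 1 to compound 2 and a 1.6-fold higher number (0.21 log units; within the scatter) from compound 3 to compound 4, 3.7-fold (0.57 log units) apart, beyond the scatter of two such steps. Read the other way, thiophen-3-yl in place of furan-2-yl gives a 1.1-fold higher number from compound 2 to compound 4 (0.06 log units; within the scatter) when cyclopentyl sits on the oxygen, again unlike the step seen with cyclobutyl there: the same change on two cores in this assay, a 4.3-fold higher number (0.63 log units; beyond the scatter) from compound 1 to compound 3 and a 1.1-fold higher number (0.06 log units; within the scatter) from compound 2 to compound 4, 3.7-fold (0.57 log units) apart, beyond the scatter of two such steps. Neither change therefore carries over at the same size from one core to the other in these four compounds, although they do not show why the steps differ or how either change would behave on any further core.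

Other groups on the oxygen, such as cyclopropyl, cyclohexyl or an open chain like isopropyl, remain open, as do other rings on the saturated ring carbon, such as thiophen-2-yl, furan-3-yl or phenyl. Such compounds could show whether the 95.1 nM of compound 1 belongs to the particular pairing of cyclobutyl with furan-2-yl or to a wider trend.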